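From compound 3 to its fluoro analogue, compound 4

The source may hold more compounds than are shown below. What is called first, only, known or untested is meant among the compounds shown, and "the series" means these compounds.

Among the measured compounds shown here, in an ADME assay on MT4 cells (Homo sapiens) for cytotoxicity, read by MTT assay (on this read-out higher numbers stand for lower toxicity in this test and lower numbers for higher toxicity in this test), compound 1 (`COc1ccc(CSc2nc(Cc3c(Cl)cccc3Cl)c(C)c(=O)[nH]2)cc1`) gives 32000 nM, the only value in this set that is not a limit. Compound 3 (`Cc1c(Cc2c(Cl)cccc2Cl)nc(SCC(=O)c2ccccc2)[nH]c1=O`) gives > 60000 nM, which is a limit of the assay and not a number. Its place on the scale is therefore known only as a limit.

Compound 4 (`Cc1c(Cc2c(Cl)cccc2Cl)nc(SCC(=O)c2ccc(F)cc2)[nH]c1=O`) differs from compound 3 by fluoro in place of hydrogen on an aromatic carbon, para to a large group: fluoro in place of hydrogen on an aromatic carbon.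

For the measured compounds named here, no measured step isolates this change. Going by the values given here, the one measured step, an at least 1.8-fold higher number from compound 1 to compound 3 (0.27 log units; that floor lies within the scatter), concerns a different group. Compound 2 (`O=C(CSc1nc(Cc2c(Cl)cccc2Cl)cc(=O)[nH]1)c1ccc(F)cc1`) also carries the (4-fluorophenyl)carbonyl group, and its > 59000 nM is again a limit.

No step beyond the scatter is expected in this assay, and no direction is expected either. The estimated step is a number no higher from compound 3 to compound 4 (the limit leaves the size open). For compound 4 the estimated value is 60000 nM, with an expected range of 30000 nM to 100000 nM.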

Compound 4, half-maximal cytotoxic concentration: > 57000 nM
Compound 4 gave a limit, no number; the forecaster's own chance of this, stated with the estimate: 75%; the middle value lies beyond the limit too.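

Compound 4 shows that fluoro in place of hydrogen on an aromatic carbon, para to a large group, still leaves the read-out at a limit in this assay: compound 4 gives > 57000 nM, which is a limit of the assay and not a number. Going by these compounds, the steps from compound 3 and from compound 2 to compound 4 cannot be read, as both ends of each are limits, so the size of this change at this position remains unknown. Among the compounds shown here, the one readable step is an at least 1.7-fold higher number from compound 1 to compound 4 (0.25 log units; that floor lies within the scatter), so this comparison does not separate the two compounds either.

On these data alone, whether an amine or a carboxylic acid in place of the fluoro would bring the read-out down to a number stays open. As far as these compounds go, what a longer chain in place of the (4-fluorophenyl)carbonyl group would give is also open.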